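The source may report more compounds than this note shows. Statements on the series, on what has been measured and on what is new or still open speak of the compounds shown alone.

Measured compounds:
Compound 1, `Cc1ccccc1-c1ccc(CCC(=O)N2CCCC2)cc1`: in an assay on HEK293 cells for inhibition of N-acylethanolamine-hydrolyzing acid amidase (Rattus norvegicus), read by LC-MS, with a stated time of 30 min (on this read-out lower numbers stand for stronger inhibition and higher numbers for weaker inhibition), compound 1 gives > 100000 nM, a limit of the assay and not a number.
Compound 2, `O=C(CCCCCCc1ccccn1)N1CCCC1`: in this assay compound 2 gives > 100000 nM, likewise a limit.

Compound 2 therefore stands at the edge of what this assay reports; (the limit of > 100000 nM in this assay, at which 2 of the 2 values shown sit), so the two values shown allow no ordering between compound 1 and compound 2. Compound 3, `O=C(CCCCCCC1CCCCC1)N1CCCC1`, has not yet been measured. It differs from compound 2 by cyclohexyl in place of pyridin-2-yl on a saturated chain carbon, six bonds along the chain from a carbonyl carbon. Among the compounds with values here, no step between measured compounds is available, so the size of this change cannot be read off; a modest move toward stronger inhibition is expected, with a fair chance that the result again comes back as a limit rather than a number. Compound 3 is expected in this assay at 50000 nM, within 10000 nM to 200000 nM. The step implied, an at least 2.0-fold lower number from compound 2 to compound 3 (0.30 log units; that floor lies within the scatter), is an estimate only.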

Compound 3, half-maximal inhibitory concentration: 5700 nM
The estimate for compound 3 lay 8.8-fold (0.94 log units) above the measured number, outside the stated range (below it).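

On a saturated chain carbon, six bonds along the chain from a carbonyl carbon, cyclohexyl in place of pyridin-2-yl gives an at least 17-fold lower number from compound 2 to compound 3 (1.24 log units; beyond the scatter). Within the data shown here, this position therefore responds to the ring it carries, and in this assay compound 3 gives 5700 nM, the only value shown that is a number. Going by these compounds, the true size of the step remains unknown, and only its floor can be stated: the limit of > 100000 nM in this assay, at which 2 of the 3 values shown sit.

The change replaces a six-membered aromatic ring with 1 hetero atom by a six-membered non-aromatic ring of carbon only, so the compounds shown cannot separate the loss of the ring nitrogen from the loss of aromaticity; a phenyl at the same place would divide the two. On these data alone, how a longer chain, or an amine on the cyclohexyl ring, would read also remains open.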